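Cytotoxicity notes: aryl swap from compound 3 to compound 4

This account rests on a few compounds, and the source may have more. Where it says the series, first, only, none or still open, it means among the compounds named here.

Measured in an ADME assay on NIH3T3 cells (Mus musculus) for cytotoxicity, read by MTT assay; a higher number here means a weaker inhibitor, a lower number a stronger inhibitor:
Compound 1 `N#Cc1c(-c2cccc(Cl)c2)c(C#N)c(=O)n(/N=C/c2cn(-c3ccccc3)nc2-c2ccccc2)c1N`: 52 ug/mL
Compound 2 `COc1ccc(-c2c(C#N)c(N)n(/N=C/c3cn(-c4ccccc4)nc3-c3ccccc3)c(=O)c2C#N)cc1`: 50 ug/mL
Compound 3 `N#Cc1c(-c2ccccc2[N+](=O)[O-])c(C#N)c(=O)n(/N=C/c2cn(-c3ccccc3)nc2-c2ccccc2)c1N`: > 200 ug/mL (a limit, not a number)

Compound 3 sits at the limit of > 200 ug/mL in this assay, at which 1 of the 3 values shown sits; its entry is a limit and not a measured number, so its true position is only bounded from below. Compounds 1 and 2 both give numbers; the step of a 1.0-fold lower number from compound 1 to compound 2 (0.02 log units; within the scatter) shows that 3-chlorophenyl and 4-methoxyphenyl give values within the scatter of each other. The two steps toward 2-nitrophenyl, an at least 3.8-fold higher number from compound 1 to compound 3 (0.58 log units; beyond the scatter) and an at least 4.0-fold higher number from compound 2 to compound 3 (0.60 log units; beyond the scatter), are the only ones that separate the three, and both point the same way.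

Compound 4 `N#Cc1c(-c2ccc(C(F)(F)F)cc2)c(C#N)c(=O)n(/N=C/c2cn(-c3ccccc3)nc2-c2ccccc2)c1N` differs from compound 3 by 4-(trifluoromethyl)phenyl in place of 2-nitrophenyl on an aromatic carbon. The aryl group that carried compound 3 to the limit leaves, and a substituted phenyl of the kind seen in compounds 1 and 2 enters. Because the steps of an at least 3.8-fold higher number from compound 1 to compound 3 (0.58 log units; beyond the scatter) and an at least 4.0-fold higher number from compound 2 to compound 3 (0.60 log units; beyond the scatter) were the only ones beyond the scatter, the expectation is a move back toward the numbers of compounds 1 and 2, the expected step being an at least 3.3-fold lower number from compound 3 to compound 4 (0.52 log units; beyond the scatter). For compound 4 the estimate in this assay is 60 ug/mL, with a range from 25 ug/mL to 200 ug/mL.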

Compound 4, half-maximal inhibitory concentration: > 200 ug/mL
Compound 4 ended at the assay's limit (the forecaster's own chance of this, stated with the estimate: 30%); middle value at least 3.3-fold (0.52 log units) away from the limit.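

In this assay compound 4 joins compound 3 at the top of the range, and its entry is a limit of the assay and not a number: the limit of > 200 ug/mL in this assay, at which 2 of the 4 values shown sit. The high reading at this position, opposite the ring nitrogen, is therefore not confined to 2-nitrophenyl, since 4-(trifluoromethyl)phenyl also separates from the two measured aryl groups, with an at least 4.0-fold higher number from compound 2 to compound 4 (0.60 log units; beyond the scatter) and an at least 3.8-fold higher number from compound 1 to compound 4 (0.58 log units; beyond the scatter). The first of these steps is the change of trifluoromethyl in place of methoxy, so a single group swap on the phenyl is enough to move the reading beyond the scatter, while compound 1 and compound 2 show that a substituted phenyl as such does not give the limit; the step between compound 3 and compound 4 cannot be read, as both entries are limits.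

From the compounds shown here alone, the true positions of compound 3 and compound 4 stay unknown, so 2-nitrophenyl and 4-(trifluoromethyl)phenyl cannot be ranked against each other. Going by these compounds, whether an aminophenyl group or a phenyl carrying a carboxylic acid at this position would read with compound 1 and compound 2 or with compound 3 and compound 4 remains open.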